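Fluoro in place of methoxy on compound 2

The compounds below may be only part of what the source reports. "The series", "measured", "known", "first", "only" and "open" are said of these compounds alone.

Measured so far in an ADME assay on Vero cells (Chlorocebus sabaeus) for cytotoxicity, read by MTT assay, with a stated time of 72 h; a lower number here means that less compound is tolerated, a higher number that more compound is tolerated:
Compound 1 `CCOC(=O)c1c(-c2ccc(OC)cc2)oc2ccc(OCCCCCCN3C(=O)C(=O)c4ccccc43)cc12`: 256 ug/mL
Compound 2 `CCOC(=O)c1c(-c2ccc(OC)cc2)oc2ccc(OCCCCCCN3C(=O)C(=O)c4cc(F)ccc43)cc12`: 1020 ug/mL

Of these two numbers in this assay, compound 2 holds the highest, at 1020 ug/mL. Compound 3 `CCOC(=O)c1c(-c2ccc(F)cc2)oc2ccc(OCCCCCCN3C(=O)C(=O)c4cc(F)ccc43)cc12` differs from compound 2 in one group: fluoro in place of methoxy on an aromatic carbon. This is fluoro in place of methoxy on an aromatic carbon, para to a large group. Among the compounds with values here, only one measured step offers any guidance: a 4.0-fold higher number from compound 1 to compound 2 (0.60 log units; beyond the scatter). That modest step was fluoro in place of hydrogen, at another place in the molecule, so it bears only loosely on this change. Within the data shown here, no measured step replaces methoxy, and the data give no firm direction. The expected step is a 1.1-fold lower number from compound 2 to compound 3 (0.05 log units; within the scatter), which would stay within the scatter. Compound 3 is estimated at 900 ug/mL, with an expected range from 300 ug/mL to 2000 ug/mL.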

Compound 3, half-maximal cytotoxic concentration: 512 ug/mL
The estimate for compound 3 lay 1.8-fold (0.24 log units) above the measured number; the measured number falls inside the stated range.
By their numbers in this assay, from the lowest: compounds 1, 3 and 2 (each within the scatter of the next, the first and the last beyond it).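

In this assay, within the data shown here, the change from 4-methoxyphenyl to 4-fluorophenyl gives a 2.0-fold lower number from compound 2 to compound 3 (0.30 log units; within the scatter), the first reading at this position, and it leaves compound 2 and compound 3 unresolved from each other. The earlier step, a 4.0-fold higher number from compound 1 to compound 2 (0.60 log units; beyond the scatter), was fluoro in place of hydrogen at another place in the molecule and lay beyond the scatter, whereas replacing methoxy with fluoro here does not. No measurement is available that bears on this result. The compounds shown leave open whether a chloro, a hydroxyl or an amine in this same place would separate from methoxy and fluoro. They also leave open whether fluoro in place of methoxy would read the same on compound 1, which carries no fluoro on its other end group.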